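The source may report more compounds than this note shows. Statements on the series, on what has been measured and on what is new or still open speak of the compounds shown alone.

Measured so far:
compound 1 `COc1ccccc1COc1cc(O)c2c(=O)c(O)c(-c3ccccc3)oc2c1` — > 100000 nM
compound 2 `N#Cc1cccc(COc2cc(O)c3c(=O)c(O)c(-c4ccccc4)oc3c2)c1` — 72000 nM

In an ADME assay on Huh-5-2 cells (Homo sapiens) for cytotoxicity, read by WST assay, with a stated time of 3 days (a higher number here means that more compound is tolerated, a lower number that less compound is tolerated), compound 1 stands at the limit of > 100000 nM in this assay, at which 1 of the 2 values shown sits, which is a limit rather than a number. Compound 2 gives 72000 nM. For the measured compounds named here, the only measured step, an at least 1.3-fold lower number from compound 1 to compound 2 (0.14 log units; that floor lies within the scatter), stays within the scatter. Compound 3 `O=c1c(O)c(-c2ccccc2)oc2cc(OCc3ccc(Cl)cc3)cc(O)c12` carries 4-chlorophenyl in place of 2-methoxyphenyl on a saturated chain carbon bound to an oxygen on an aromatic ring. Going by the values given here, that step from compound 1 to compound 2 is the only one bearing on this change, and it shows no movement beyond the scatter. For compound 3 the expected step is therefore an at least 1.2-fold lower number from compound 1 to compound 3 (0.09 log units; that floor lies within the scatter) in this assay. Compound 3 is estimated at 80000 nM, between 35000 nM and 150000 nM.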

Compound 3, half-maximal cytotoxic concentration: > 100000 nM
Compound 3: a limit, no number; the forecaster's own chance of this, stated with the estimate: 40%; middle value at least 1.2-fold (0.09 log units) from the limit.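

In this assay compound 3 gives > 100000 nM, which is a limit and not a number. With 4-chlorophenyl on this saturated chain carbon, an at least 1.3-fold higher number from compound 2 to compound 3 (0.14 log units; that floor lies within the scatter), so exchanging 3-cyanophenyl for 4-chlorophenyl shows no movement beyond the scatter. The step between compound 1 and compound 3 cannot be read, and the series now sits largely at the assay ceiling: the limit of > 100000 nM in this assay, at which 2 of the 3 values shown sit.

As far as these compounds go, whether any group at this place lowers the number beyond the scatter remains open, for instance a phenyl ring carrying an amine or a carboxylic acid, or a longer chain. From the compounds shown here alone, how far compound 1 and compound 3 lie past the limit also remains open.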